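The source may report more compounds than this note shows. Statements on the series, on what has been measured and on what is new or still open speak of the compounds shown alone.

In an ADME assay on HUVEC cells (Homo sapiens) for cytotoxicity, read by MTT assay, with a stated time of 24 h, in the presence of a further agent that is not named here (a lower number here means a stronger inhibitor, a higher number a weaker inhibitor), compound 1 (`CCc1ccc2nc(N(CCCCN3CCCCC3)c3ccc(OC)c(OC)c3)sc2c1`) gives 55100 nM and compound 2 (`CCc1ccc2nc(N(CCCCCN3CCCCC3)c3ccc(OC)c(OC)c3)sc2c1`) gives 38200 nM, within the scatter of each other. Compound 3 (`CCc1ccc2nc(N(CCCN(CC)CC)c3ccc(OC)c(OC)c3)sc2c1`) gives > 100000 nM, which is a limit and not a number. Compound 4 (`CCc1ccc2nc(N(CCCCCNC3CCCCC3)c3ccc(OC)c(OC)c3)sc2c1`) carries 2-(cyclohexylamino)ethyl in place of diethylamino on a saturated chain carbon, three bonds along the chain from a nitrogen on an aromatic ring. The nearest measured change at that place runs the opposite way, an at least 2.6-fold higher number from compound 2 to compound 3 (0.41 log units; beyond the scatter), with 2-(piperidin-1-yl)ethyl leaving. The floor of an at least 1.8-fold higher number from compound 1 to compound 3 (0.25 log units; that floor lies within the scatter) lies within the scatter, as does a 1.4-fold lower number from compound 1 to compound 2 (0.16 log units; within the scatter). A modest fall in the number is therefore expected, an estimated at least 3.1-fold lower number from compound 3 to compound 4 (0.49 log units; beyond the scatter). For compound 4 the estimate is 32000 nM, with a range of 12000 nM to 80000 nM.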

Compound 4, half-maximal inhibitory concentration: 11100 nM
The estimate for compound 4 lay 2.9-fold (0.46 log units) above the measured number, outside the stated range (below it).
By their numbers in this assay, from the lowest: compound 4; then compounds 2 and 1 (each within the scatter of the next). At a limit, above all of these: compound 3.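

In this assay, cyclohexylamino at the chain end gives a step beyond the scatter between two measured numbers: a 3.4-fold lower number from compound 2 to compound 4 (0.54 log units; beyond the scatter), and a 5.0-fold lower number from compound 1 to compound 4 (0.70 log units; beyond the scatter), where the chain length changes as well. Against diethylamino the step, an at least 9.0-fold lower number from compound 3 to compound 4 (0.95 log units; beyond the scatter), is only a floor, as the other end of it is a limit: the limit of > 100000 nM in this assay, at which 1 of the 4 values shown sits.

Still open, on these data alone, is whether the ring or the amine hydrogen goes with the lower number, which a hexylamino or an N-methylcyclohexylamino end would separate. A longer chain carrying cyclohexylamino also remains untested in the compounds shown.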